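Compound 4: swapping the aryl group on sulfur

This account rests on a few compounds, and the source may have more. Where it says the series, first, only, none or still open, it means among the compounds named here.

Measured in a functional assay on A549 cells (Homo sapiens) for inhibition, read by CCK-8 assay, with a stated time of 72 h, tested at 8 uM; on this read-out lower numbers stand for less inhibition of growth and higher numbers for more inhibition of growth at the one concentration tested:
- compound 1 `Nc1ccccc1NC(=O)/C=C/c1ccc(CSc2cccc(F)c2)cc1`: 56.6%
- compound 2 `CCc1ccc(SCc2ccc(C(=O)Nc3ccccc3N)cc2)cc1`: 91.4%
- compound 3 `Nc1ccccc1NC(=O)c1ccc(CSc2cccc(F)c2)cc1`: 72.7%

Compound 1 stands lowest of these three, clearly under both compound 3 and compound 2. The next compound, compound 4 `Cc1ccc(SCc2ccc(/C=C/C(=O)Nc3ccccc3N)cc2)cc1`, keeps the core of compound 1 and changes one group: 4-methylphenyl in place of 3-fluorophenyl on a sulfur. In words, 4-methylphenyl sits in place of 3-fluorophenyl on a sulfur.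

Going by the values given here, one measured step bears on this change: a number 18.7 percentage points lower from compound 2 to compound 3 (beyond the scatter), with 3-fluorophenyl in place of 4-ethylphenyl on a sulfur. That step runs in the opposite direction, involves an ethyl rather than a methyl group, and was measured on a different core, so it is only a loose guide. Read in reverse, it points upward, and a moderate rise is expected in this assay. The estimated step is a number 12.4 percentage points higher from compound 1 to compound 4 (beyond the scatter). For compound 4 the expected value is 69%, with an estimated range of 54% to 85%.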

Compound 4, percent growth inhibition at one concentration: 48.3%
Compound 4: middle estimate off by 20.7 percentage points, on the high side, outside the stated range (below it).
By their numbers in this assay, from the lowest: compounds 4 and 1 (each within the scatter of the next); then compound 3; then compound 2.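

On the core of compound 1, in this assay, 4-methylphenyl in place of 3-fluorophenyl on a sulfur gives a number 8.3 percentage points lower from compound 1 to compound 4 (within the scatter), so this change does not separate the two compounds on this read-out. The other listed change on this sulfur, a number 18.7 percentage points lower from compound 2 to compound 3 (beyond the scatter), with 3-fluorophenyl in place of 4-ethylphenyl, goes beyond the scatter, so a swap here moves the number in that pair but not in this one, although the pairs differ in both the core and the group replaced. No measurement at hand accounts for this contrast.

The compounds shown leave open whether the contrast follows the ethyl group or the core, since 4-ethylphenyl does not appear on the core of compound 1. From the compounds shown here alone, how an aryl group carrying a methoxy group or a chlorine atom would read on this sulfur also remains open.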